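Adding a second methoxy to compound 1

The compounds below may be only part of what the source reports. "The series", "measured", "known", "first", "only" and "open" are said of these compounds alone.

Measured in a functional assay on KB cells (Homo sapiens) for antiproliferative activity, read by sulforhodamine B assay, with a stated time of 3 days; on this read-out lower numbers stand for an effect already at smaller amounts and higher numbers for an effect only at larger amounts of compound:
- Compound 1 `CCC1=C(O)c2c(oc(-c3cccc(OC)c3)cc2=O)C(CC)(CC)C1=O`: 13.3 uM
- Compound 2 `CCC1=C(O)c2c(oc(-c3ccccc3F)cc2=O)C(CC)(CC)C1=O`: > 56.2 uM, a limit of the assay
- Compound 3 `CCC1=C(O)c2c(oc(-c3ccc(OC)c(OC)c3)cc2=O)C(CC)(CC)C1=O`: 14.7 uM

Among the measured compounds shown here, compound 1 holds one of only two exact numbers, level with compound 3. Compound 4 `CCC1=C(O)c2c(oc(-c3cccc(OC)c3OC)cc2=O)C(CC)(CC)C1=O` has methoxy in place of hydrogen on an aromatic carbon, ortho to a large group and ortho to a methoxy group (methoxy in place of hydrogen on an aromatic carbon). For the measured compounds named here, the closest precedent is the same kind of change, a 1.1-fold higher number from compound 1 to compound 3 (0.04 log units; within the scatter). The other step, an at least 4.2-fold higher number from compound 1 to compound 2 (0.62 log units; beyond the scatter), puts 2-fluorophenyl in place of 3-methoxyphenyl and shows that the number can climb in this series. Little change, perhaps tilted upward, is expected in this assay: the estimated step is a 1.4-fold higher number from compound 1 to compound 4 (0.15 log units; within the scatter). For compound 4 the estimated value is 19 uM, with an expected range of 9 uM to 45 uM.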

Compound 4, concentration for half-maximal effect: 35.2 uM
Beside the measured number, compound 4's estimate is 1.9-fold (0.27 log units) below it; the measured number falls inside the stated range.
By their numbers in this assay, from the lowest: compounds 1 and 3 (each within the scatter of the next); then compound 4. At a limit, above all of these: compound 2.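

Measured in this assay the added methoxy, ortho to a large group and ortho to a methoxy group, gives a 2.6-fold higher number from compound 1 to compound 4 (0.42 log units; beyond the scatter) and so counts as a modest step. The same kind of change in its other placement gives a 1.1-fold higher number from compound 1 to compound 3 (0.04 log units; within the scatter) and so shows that, across these two cases, the outcome depends on where the methoxy lands. Nothing in the data shown explains this difference. From the compounds shown here alone, whether a hydroxyl or an amine at this same place would give a similar step stays open.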